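The compounds below may be only part of what the source reports. "The series", "measured", "known", "first", "only" and "open" are said of these compounds alone.

Measured so far:
- compound 1 `C=C1CCC[C@H]2[C@](C)(CC[C@]3(C)CC[C@@H]([C@@H](C)C(=O)O)OO3)[C@@H](C)CC[C@]12C`: 1000 nM
- compound 2 `C=C1CCCC(C)(C)C1CC[C@@]1(C)CC[C@H]([C@@H](C)C(=O)O)OO1`: 7610 nM

In a functional assay on NCI-H23 cells (Homo sapiens) for inhibition (on this read-out higher numbers stand for weaker inhibition of growth and lower numbers for stronger inhibition of growth), compound 1 stands lowest of the two numbers; compound 2 gives the higher number, and the gap between them lies beyond the scatter. Compound 3 `C=C1CCC[C@H]2[C@](C)(CC[C@]3(C)CC[C@H]([C@@H](C)C(=O)O)OO3)[C@@H](C)CC[C@]12C` is not yet measured. Compared with compound 1, (the two compounds have the same atoms and bonds and differ only in configuration as drawn: 1 of 7 stereo elements differ; a stereocentre at a saturated ring carbon is drawn S in compound 1 and R in compound 3). Among the measured compounds shown here, no measured pair differs in one place, so no comparable step is known. A single inversion at a saturated ring carbon is expected to move the number by a modest amount, direction uncertain, and the step of a 1.6-fold higher number from compound 1 to compound 3 (0.20 log units; within the scatter) is estimated as a slight rise. Compound 3 is expected to give 1600 nM (range 400 nM to 6000 nM).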

Compound 3, concentration for 50% growth inhibition: 2020 nM
Beside the measured number, compound 3's estimate is 1.3-fold (0.10 log units) below it; the measured number falls inside the stated range.
By their numbers in this assay, from the lowest: compound 1; then compound 3; then compound 2.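

Configuration at this saturated ring carbon registers in this assay: going from S to R gives a 2.0-fold higher number from compound 1 to compound 3 (0.31 log units; beyond the scatter), the first step in the series that changes one place only. The step is modest, and the S form gives the lower number of the pair. It can be set on this one stereocentre because nothing else separates the pair: the fact that compounds 1 and 3 differ only in the configuration as drawn

Open, as far as these compounds go, is whether the same inversion moves the number likewise on the core of compound 2, and how the other stereo elements weigh. Also open, from the compounds shown here alone, is whether the order of S and R holds when a methyl ester or an amide replaces the carboxylic acid.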